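Adding a Benzyl Group: Expected Effect on Cell Toxicity

The source may hold more compounds than are shown below. What is called first, only, known or untested is meant among the compounds shown, and "the series" means these compounds.

Measured so far:
Compound 1, `CCCC(=O)OCSc1ccccc1C(=O)NCC(N)=O` — in an ADME assay on CEM-SS cells (Homo sapiens) for cytotoxicity, read by XTT assay, with a stated time of 6 days (on this read-out lower numbers stand for higher toxicity in this test and higher numbers for lower toxicity in this test), compound 1 gives > 100 uM, a limit of the test rather than a number.
Compound 2, `CCCC(=O)OCSc1ccccc1C(=O)OCC(N)=O` — in this assay compound 2 gives 82.1 uM.

Compound 1 sits at the limit of > 100 uM in this assay, at which 1 of the 2 values shown sits, so for compound 1 only a limit is known and no exact number. Among the compounds with values here, the one measured step, an at least 1.2-fold lower number from compound 1 to compound 2 (0.08 log units; that floor lies within the scatter), replaces (carbamoylmethyl)amino with carbamoylmethoxy on a carbonyl carbon, and its floor lies within the scatter, so it shows no clear change in toxicity.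

Compound 3, `CCCC(=O)OCSc1ccccc1C(=O)NCC(=O)NCc1ccccc1`, has not yet been measured. It differs from compound 1 by benzyl in place of hydrogen on an amide-type nitrogen. Within the data shown here, no measured step touches this part of the molecule, and the only step available concerns a different group and stays within the scatter. There is therefore no measured basis to expect a step beyond the scatter in either direction, and both measured compounds sit at low toxicity.

Compound 3 is expected to give about 90 uM in this assay, within a range of 35 uM to 250 uM. The step this estimate means is an at least 1.1-fold lower number from compound 1 to compound 3 (0.04 log units; that floor lies within the scatter), which is not expected to exceed the scatter.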

Compound 3, half-maximal toxic concentration: 29.3 uM
Compound 3: the middle estimate sits 3.1-fold (0.49 log units) above what was measured, outside the stated range (below it).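

Until now, the only measured step concerned a different part of the molecule and stayed within the scatter, so it gave no sign that any part of these compounds affects toxicity. Compound 3 supplies that sign: in this assay, benzyl in place of hydrogen on an amide-type nitrogen gives an at least 3.4-fold lower number from compound 1 to compound 3 (0.53 log units; beyond the scatter), which means higher toxicity in this test for the benzyl compound. The real size of this step may be larger, because compound 1 has only a limit of the test and no exact number: the limit of > 100 uM in this assay, at which 1 of the 3 values shown sits.

The compounds shown leave open whether the aromatic ring of the benzyl group matters or whether other carbon groups on this nitrogen would have the same effect; a methyl group, a cyclohexylmethyl group or a longer chain in the same place would help separate these possibilities. They also leave open why toxicity rises with this change and whether the same change would have a similar effect on a different core.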